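This account rests on a few compounds, and the source may have more. Where it says the series, first, only, none or still open, it means among the compounds named here.

Measured compounds:
compound 1 `O=C(CCCc1nc2ccccc2c(=O)[nH]1)N/N=C/c1cc(O)c(O)c(O)c1` — 45000000 nM
compound 2 `COc1cc(/C=N/NC(=O)CCCc2nc3ccccc3c(=O)[nH]2)cc(O)c1O` — 80000000 nM
compound 3 `O=C(CCc1nc2ccccc2c(=O)[nH]1)N/N=C/c1cc(O)c(O)c(O)c1` — 45000000 nM

All three were read in a physicochemical assay, read by spectrophotometry, with a stated time of 15 min; a lower number here means a stronger inhibitor, a higher number a weaker inhibitor. In this assay compound 1 gives 45000000 nM, compound 2 gives 80000000 nM and compound 3 gives 45000000 nM. Compound 2 arises from compound 1 by methyl in place of hydrogen on an oxygen on an aromatic ring; the step this change made was a 1.8-fold higher number from compound 1 to compound 2 (0.25 log units; within the scatter). Compound 3 and compound 1 differ in their cores; the difference between the two cores is not broken down here. At the digits given compound 3 and compound 1 agree, and the gap from either to compound 2 lies within the scatter.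

Compound 4 `COc1cc(/C=N/NC(=O)CCc2nc3ccccc3c(=O)[nH]2)cc(O)c1O` is not yet measured. It stands to compound 3 as compound 2 stands to compound 1: methyl in place of hydrogen on an oxygen on an aromatic ring. The surroundings of the place read the same word for word in both cases, so this is the same change made on the core of compound 3. The earlier step stayed within the scatter, and the expectation here is a 1.7-fold higher number from compound 3 to compound 4 (0.22 log units; within the scatter), resting on the measured 1.8-fold higher number from compound 1 to compound 2 (0.25 log units; within the scatter). Compound 4 is estimated at 75000000 nM, with a range from 35000000 nM to 160000000 nM.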

Compound 4, half-maximal inhibitory concentration: 50000000 nM
Estimate against measurement, compound 4: 1.5-fold (0.18 log units) above, and the stated range covers the measured number.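

In this assay the change from hydroxy to methoxy gives a 1.8-fold higher number from compound 1 to compound 2 (0.25 log units; within the scatter) on the first core and a 1.1-fold higher number from compound 3 to compound 4 (0.05 log units; within the scatter) on the second, and both steps lie within the scatter. The change therefore carries across these two cores without a step that can be told from repeat-measurement noise, but two such pairs cannot separate a small real effect from none and say nothing about a third core or about a step beyond the scatter. Nothing given here bears on why the two steps read as they do.

The compounds shown leave open whether an amine or a carboxylic acid on the aromatic ring in place of the hydroxy group would read differently from the hydroxy and methoxy compounds. They also leave open whether a longer chain than methyl on that oxygen would stay within the scatter on either core.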